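Aminoheteroaryl variation on the shared core, towards a triazole

The source may hold more compounds than are shown below. What is called first, only, known or untested is meant among the compounds shown, and "the series" means these compounds.

Compound 3 `Cc1ccc(CNC(=O)c2cccc(C(C)Oc3cccnc3Nc3ncc(C)s3)c2)cc1` gives 8500 nM in a functional assay on NCI-H3122 cells (Homo sapiens) for antiproliferative activity, read by MTT assay, with a stated time of 48 h; a lower number here means a stronger inhibitor, a higher number a weaker inhibitor. Among the measured compounds shown here, this is the lowest of the three numbers so far, but both neighbours sit within the scatter of it: compound 1 `Cc1ccc(CNC(=O)c2cccc(C(C)Oc3cccnc3Nc3cnn(CC(C)(C)O)c3)c2)cc1` gives 9100 nM in this assay, and compound 2 `Cc1ccc(CNC(=O)c2cccc(C(C)Oc3cccnc3Nc3nccs3)c2)cc1` gives 15300 nM. The measured steps accordingly show no movement beyond the scatter: a 1.1-fold lower number from compound 1 to compound 3 (0.03 log units; within the scatter), a 1.7-fold higher number from compound 1 to compound 2 (0.23 log units; within the scatter) and a 1.8-fold lower number from compound 2 to compound 3 (0.26 log units; within the scatter). Exchanging the group on the nitrogen has so far left the read-out essentially flat.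

Compound 4 `Cc1ccc(CNC(=O)c2cccc(C(C)Oc3cccnc3Nn3cnnc3)c2)cc1` is not yet measured. The change from compound 3 is 4H-1,2,4-triazol-4-yl in place of 5-methyl-1,3-thiazol-2-yl on a nitrogen on an aromatic ring. For the measured compounds named here, every measured step that touches this position, from compound 1 to compound 2, from compound 1 to compound 3 and from compound 2 to compound 3, stayed within the scatter, and there is no measured example of the entering group anywhere. Given the flat picture, no step beyond the scatter is expected in this assay, with a wide range allowed because the new group is untested; the expected step is a 1.4-fold higher number from compound 3 to compound 4 (0.15 log units; within the scatter). Compound 4 is estimated at 12000 nM, with a range of 4000 nM to 40000 nM.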

Compound 4, half-maximal inhibitory concentration: 23700 nM
For compound 4 the middle estimate is 2.0-fold (0.30 log units) below the measured one; measured number inside the range.
By their numbers in this assay, from the lowest: compounds 3, 1, 2 and 4 (each within the scatter of the next, the first and the last beyond it).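

In this assay, among the compounds shown here, the group on the nitrogen is no longer flat: a 2.8-fold higher number from compound 3 to compound 4 (0.45 log units; beyond the scatter) and a 2.6-fold higher number from compound 1 to compound 4 (0.42 log units; beyond the scatter) are the first steps at this position to pass the scatter, and both are modest. The separation is not general, as a 1.5-fold higher number from compound 2 to compound 4 (0.19 log units; within the scatter) does not pass it, so 4H-1,2,4-triazol-4-yl stands apart from 5-methyl-1,3-thiazol-2-yl and from 1-(2-hydroxy-2-methylpropyl)-1H-pyrazol-4-yl but not from 1,3-thiazol-2-yl. No measurement of any property of these compounds is available to account for this pattern.

The compounds shown leave open whether a methyl on the triazole ring would change the read-out, given that on the thiazole ring methyl gives only a 1.8-fold lower number from compound 2 to compound 3 (0.26 log units; within the scatter) and so stays within the scatter. Also open, going by these compounds, is how a longer chain ending in an amine or a carboxylic acid, in place of the 2-hydroxy-2-methylpropyl chain on the pyrazole of compound 1, would read in this assay on the shared core.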